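Series notes: fluoro for bromo on the benzyl group

This account rests on a few compounds, and the source may have more. Where it says the series, first, only, none or still open, it means among the compounds named here.

Measured in a functional assay on A549 cells (Homo sapiens) for inhibition, read by MTT assay, with a stated time of 48 h, tested at 10 uM; on this read-out higher numbers stand for more inhibition of growth at the one concentration tested and lower numbers for less inhibition of growth:
compound 1, `C#CCOc1ccc(/C=C/C(=O)c2ccc(Br)cc2)cc1`: 34%
compound 2, `O=C(/C=C/c1ccc(OCc2cn(Cc3ccccc3Br)nn2)cc1)c1ccc(Br)cc1`: 44%
compound 3, `COc1ccc(C(=O)/C=C/c2ccc(OCc3cn(Cc4ccccc4Br)nn3)cc2)cc1`: 52%

Compound 3 gives the highest of the three numbers in this assay. Its nearest neighbour is compound 2, and the step of a number 8 percentage points higher from compound 2 to compound 3 (within the scatter) stays within the scatter, so compound 3 and compound 2 cannot be ranked against each other. Only compound 1 sits beyond the scatter below compound 3.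

Compound 4, `COc1ccc(C(=O)/C=C/c2ccc(OCc3cn(Cc4ccccc4F)nn3)cc2)cc1`, is not yet measured. It differs from compound 3 in one place: fluoro in place of bromo on an aromatic carbon. Going by the values given here, no measured step swaps one halogen for another; the one measured step, a number 8 percentage points higher from compound 2 to compound 3 (within the scatter), replaces bromo with methoxy on a different aromatic carbon and stays within the scatter. Among the compounds with values here, nothing among the measured compounds therefore supports a step beyond the scatter in this assay, in either direction, and the expected step for compound 4 is a number 4 percentage points lower from compound 3 to compound 4 (within the scatter). Compound 4 is estimated at 48% in this assay, with a range from 33% to 63%.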

Compound 4, percent growth inhibition at one concentration: 21%
Compound 4: middle estimate off by 27 percentage points, on the high side, outside the stated range (below it).
By their numbers in this assay, from the lowest: compound 4; then compounds 1, 2 and 3 (each within the scatter of the next, the first and the last beyond it).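

Going from 2-bromobenzyl to 2-fluorobenzyl gives a number 31 percentage points lower from compound 3 to compound 4 (beyond the scatter) in this assay. This is the first step between compounds differing in one place to pass beyond the scatter; the earlier step, a number 8 percentage points higher from compound 2 to compound 3 (within the scatter), concerned a different aromatic carbon and stayed within it, so this aromatic carbon, ortho to a large group, is the first place in the series shown to respond to a single-atom exchange. No measurement at hand accounts for the difference between bromo and fluoro at this place.

Open, as far as these compounds go, is whether chloro, methyl or an amine at this place would stay near compound 3 or fall toward compound 4. Also open, from the compounds shown here alone, is whether fluoro for bromo here gives a step of like size when the methoxy of compound 3 is replaced by the bromo of compound 2.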